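The source may report more compounds than this note shows. Statements on the series, on what has been measured and on what is new or still open speak of the compounds shown alone.

Of the compounds shown here, two of this set have so far been measured in a functional assay on UO-31 cells (Homo sapiens) for antiproliferative activity, read by sulforhodamine B assay, with a stated time of 72 h; on this read-out lower numbers stand for stronger inhibition and higher numbers for weaker inhibition. Compound 1 `Clc1ccc(C(/C=C/c2ccccc2)=N\Nc2nncc3ccccc23)cc1` gives 6.2 nM and compound 2 `O=S(=O)(Nc1ccccn1)c1ccc(Nc2nncc3ccccc23)cc1` gives 44 nM, the higher of the two numbers, with a gap between them that lies beyond the scatter. Compound 3 `NS(=O)(=O)c1ccc(Nc2nncc3ccccc23)cc1` has not yet been measured. It differs from compound 2 by hydrogen in place of pyridin-2-yl on a sulfonamide nitrogen, the rest of the molecule unchanged. For the measured compounds named here, no measured pair shows this change in this assay, so the expected step, a 1.4-fold higher number from compound 2 to compound 3 (0.13 log units; within the scatter), is estimated to stay within the scatter. Compound 3 is therefore expected to give about 60 nM, in a range from 20 nM to 200 nM.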

Compound 3, half-maximal inhibitory concentration: 23 nM
Compound 3: middle estimate off by 2.6-fold (0.42 log units), on the high side, within the range that was stated.
By their numbers in this assay, from the lowest: compound 1; then compounds 3 and 2 (each within the scatter of the next).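

In this assay, hydrogen in place of pyridin-2-yl on a sulfonamide nitrogen gives a 1.9-fold lower number from compound 2 to compound 3 (0.28 log units; within the scatter) and so leaves the two compounds indistinguishable. For the compounds shown here, this is the first sign that this nitrogen can carry either hydrogen or the whole six-membered aromatic ring with no change beyond the scatter. Nothing available accounts for this result. Still open, going by these compounds, is how a methyl or acetyl group on the same nitrogen would read, or a phenyl ring in place of pyridin-2-yl.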